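The compounds below may be only part of what the source reports. "The series", "measured", "known", "first", "only" and "open" are said of these compounds alone.

Compound 1, `Cc1ccc(-c2csc(NC(=O)COc3ccccc3)n2)cc1`, gives 41700 nM.
Compound 2, `Cc1ccc(-c2csc(NC(=O)COc3ccccc3C)n2)cc1`, gives 50900 nM.
Compound 3, `O=C(COc1ccccc1)Nc1nc(-c2ccc(Br)cc2)cs1`, gives 52900 nM.

All three were tested in a functional assay on A549 cells (Homo sapiens) for cytotoxicity, read by MTT assay, with a stated time of 48 h; on this read-out higher numbers stand for weaker inhibition and lower numbers for stronger inhibition. Compound 4, `Cc1ccccc1OCC(=O)Nc1nc(-c2ccc(Br)cc2)cs1`, has not yet been measured there. It is made from compound 3 by the change (methyl in place of hydrogen on an aromatic carbon). The same change was already made once, from compound 1 to compound 2, as methyl in place of hydrogen on an aromatic carbon, and it gave a 1.2-fold higher number from compound 1 to compound 2 (0.09 log units; within the scatter). The two cores on which this change is made differ by bromo in place of methyl on an aromatic carbon, with a 1.3-fold higher number from compound 1 to compound 3 (0.10 log units; within the scatter). Because that earlier step gave a 1.2-fold higher number from compound 1 to compound 2 (0.09 log units; within the scatter), the step from compound 3 to compound 4 in this assay is expected to be small as well, about a 1.1-fold higher number from compound 3 to compound 4 (0.05 log units; within the scatter). Compound 4 is therefore estimated to give 60000 nM, with a likely range from 30000 nM to 120000 nM.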

Compound 4, half-maximal inhibitory concentration: 50100 nM
The estimate for compound 4 lay 1.2-fold (0.08 log units) above the measured number; the range from low to high includes it.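

In this assay, changing phenoxy to 2-methylphenoxy on the bromo-bearing core gives a 1.1-fold lower number from compound 3 to compound 4 (0.02 log units; within the scatter), and this step agrees with the same change on the methyl-bearing core: the same change on two cores in this assay, a 1.2-fold higher number (0.09 log units; within the scatter) from compound 1 to compound 2 and a 1.1-fold lower number (0.02 log units; within the scatter) from compound 3 to compound 4, 1.3-fold (0.11 log units) apart, within the scatter of two such steps. Putting bromo in place of methyl gives a 1.0-fold lower number from compound 2 to compound 4 (0.01 log units; within the scatter), which also agrees with its earlier counterpart: the same change on two cores in this assay, a 1.3-fold higher number (0.10 log units; within the scatter) from compound 1 to compound 3 and a 1.0-fold lower number (0.01 log units; within the scatter) from compound 2 to compound 4, 1.3-fold (0.11 log units) apart, within the scatter of two such steps. Both changes therefore carry over between these cores, but only as steps within the scatter, so this does not show that a change with a clear effect would carry over, or that either change would behave the same on any other core.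

The compounds shown leave open what an amine or a carboxylic acid would do in place of the added methyl. They also leave open the effect of a longer chain in place of the bromo.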